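This account rests on a few compounds, and the source may have more. Where it says the series, first, only, none or still open, it means among the compounds named here.

Measured so far in this series:

Compound 2, `CN(C)C(=O)/C=C1\CCc2c(F)cc(F)cc21`: 100%
Compound 1, `O=C(/C=C1\CCc2cc(Cl)ccc21)NC1CC1`: 17%

In a functional assay on the whole organism with Mus musculus as the target, at a dose of 100 mg/kg by the intraperitoneal route (a lower number here means less inhibition, a higher number more inhibition at the dose given (going by the name of the read-out)), compound 2 gives 100%, the highest of the two numbers in hand. Compound 1 gives 17%, a gap beyond the scatter; compound 1 differs from compound 2 in more than one place, so its value says nothing direct about any single change.

The next compound, compound 3, `CCNC(=O)/C=C1\CCc2c(F)cc(F)cc21`, keeps the core of compound 2 and alters only the amide: ethylamino in place of dimethylamino on a carbonyl carbon. Within the data shown here, no pair with just this one difference has been measured, so the size of the step is unknown. Compound 1 also carries an amide with one hydrogen-bond donor and sits low, but on a different core, so that is weak guidance.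

Compound 3 is expected to give a somewhat lower number, an estimated 70% (range 30% to 100%). The step from compound 2 to compound 3 is thus expected to be a modest fall, a number 30 percentage points lower from compound 2 to compound 3 (beyond the scatter).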

Compound 3, a percentage reported as inhibition, in the whole organism at one dose (the size of the read-out at that dose, not a potency): 67%
Compound 3: middle estimate off by 3 percentage points, on the high side; measured number inside the range.
By their numbers in this assay, from the lowest: compound 1; then compound 3; then compound 2.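

Among these compounds, with the core held constant, ethylamino in place of dimethylamino on a carbonyl carbon gives a number 33 percentage points lower from compound 2 to compound 3 (beyond the scatter) in this assay, the first single change that can be read. The two groups hold the same count of heavy atoms and differ in the hydrogen-bond donor that ethylamino carries, so this position responds to a change that adds no atoms to the molecule. Nothing measured on these compounds gives a reason for the step.

On these data alone, whether the fall follows the hydrogen-bond donor or the ethyl chain itself stays open, since the two change together in this single pair. Also open, as far as these compounds go, is how a ring amine such as pyrrolidine or morpholine, or a longer chain such as diethylamino, would behave on the same carbonyl carbon.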